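Aryl Variation on the Shared Core: Compound 3 to Compound 4

The source may hold more compounds than are shown below. What is called first, only, known or untested is meant among the compounds shown, and "the series" means these compounds.

Compound 3 `COc1cc(-n2cnc3ccc(-c4ccc(Cl)cc4)cc32)cc(OC)c1OC` gives 1270 nM in a functional assay on SGC-7901 cells (Homo sapiens) for antiproliferative activity, read by MTT assay, with a stated time of 72 h (a lower number here means a stronger inhibitor, a higher number a weaker inhibitor), the highest of the two numbers in hand, though within the scatter of its neighbour. That neighbour, compound 2 `COc1cc(-n2cnc3ccc(-c4ccc(C(F)(F)F)cc4)cc32)cc(OC)c1OC`, gives 890 nM, and the step of a 1.4-fold higher number from compound 2 to compound 3 (0.15 log units; within the scatter). Compound 1 `COc1cc(-c2ccc3ncn(-c4cc(OC)c(OC)c(OC)c4)c3c2)cc(OC)c1OC` reaches only the limit > 10000 nM; here the limit of > 10000 nM in this assay, at which 1 of the 3 values shown sits, applies, and no number is known for compound 1. Compound 4 `COc1ccccc1-c1ccc2ncn(-c3cc(OC)c(OC)c(OC)c3)c2c1` differs from compound 3 as follows: 2-methoxyphenyl in place of 4-chlorophenyl on an aromatic carbon. Going by the values given here, the only measured step, from compound 2 to compound 3, exchanged one small group at this place and stayed within the scatter, so it bears weakly on the present change; no other pair informs it. Compound 1 shows that another aryl group at this place can reach the limit. The estimate for compound 4 is 2500 nM, with an expected range of 800 nM to 10000 nM. This corresponds to an expected step of a 2.0-fold higher number from compound 3 to compound 4 (0.29 log units; within the scatter).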

Compound 4, half-maximal inhibitory concentration: 5050 nM
The estimate for compound 4 lay 2.0-fold (0.31 log units) below the measured number; the measured number falls inside the stated range.
By their numbers in this assay, from the lowest: compounds 2 and 3 (each within the scatter of the next); then compound 4. At a limit, above all of these: compound 1.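

At this position a step beyond the scatter now appears, with a 4.0-fold higher number from compound 3 to compound 4 (0.60 log units; beyond the scatter) and with a 5.7-fold higher number from compound 2 to compound 4 (0.75 log units; beyond the scatter) when 2-methoxyphenyl enters. The change thus separates 2-methoxyphenyl from 4-chlorophenyl and 4-(trifluoromethyl)phenyl, two groups whose compounds lie within the scatter of each other. Nothing in the data shown accounts for this step.

On these data alone, whether 4-methoxyphenyl would read like compound 3 or like compound 4 remains open. So does the reading in this assay for an aryl group carrying an amine or a carboxylic acid at this place.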